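This account rests on a few compounds, and the source may have more. Where it says the series, first, only, none or still open, it means among the compounds named here.

Measured so far:
compound 1, `CCCc1n[nH]c2c(=O)n(NC(=O)c3ccccc3)c(-c3cccc([N+](=O)[O-])c3)nc12`: 27.8%
compound 2, `CCCc1n[nH]c2c(=O)n(NC(=O)c3ccccc3)c(-c3cccc(OC)c3)nc12`: 23.6%
compound 3, `COc1cccc(-c2nc3c(-c4ccc(Cl)cc4)n[nH]c3c(=O)n2NC(=O)c2ccccc2)c1`: 94.1%

In a functional assay on DU-145 cells (Homo sapiens) for cytotoxicity, read by sulforhodamine B assay, with a stated time of 2 days, tested at 100 uM (a lower number here means less inhibition, a higher number more inhibition at the concentration tested (going by the name of the read-out)), compound 1 stands second highest of the three, with compound 2 within the scatter of it (a number 4.2 percentage points lower from compound 1 to compound 2 (within the scatter)) and compound 3 far above it. Compound 4, `O=C(Nn1c(-c2cccc([N+](=O)[O-])c2)nc2c(CCc3ccccc3)n[nH]c2c1=O)c1ccccc1`, differs from compound 1 by phenyl in place of methyl on a saturated chain carbon, two bonds along the chain from an aromatic carbon. Among the compounds with values here, no measured step changes the chain in this way. Within the data shown here, the one step that touches the same position, a number 70.5 percentage points higher from compound 2 to compound 3 (beyond the scatter), puts an aryl group directly on the aromatic carbon in place of propyl and is large; compound 4 keeps the chain and adds the ring at its end, so only part of that effect is expected, upward. Compound 4 is therefore estimated at 45%, between 20% and 80%, meaning an expected a number 17.2 percentage points higher from compound 1 to compound 4 (beyond the scatter).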

Compound 4, a percentage reported as inhibition, at one concentration (the size of the read-out at that concentration, not a potency): 92.5%
Compound 4: the middle estimate sits 47.5 percentage points below what was measured; the whole stated range lies below it.
By their numbers in this assay, from the lowest: compounds 2 and 1 (each within the scatter of the next); then compounds 4 and 3 (each within the scatter of the next).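

In this assay, a phenyl ring at the end of the chain is enough for a large rise: a number 64.7 percentage points higher from compound 1 to compound 4 (beyond the scatter). The position therefore gives a large upward step without an aryl group directly on the aromatic carbon, as in a number 70.5 percentage points higher from compound 2 to compound 3 (beyond the scatter), although that step carries methoxy where this one carries nitro. Nothing at hand explains the rise.

Open, on these data alone, is whether a benzyl group or a longer chain ending in phenyl gives a similar number. Also open, as far as these compounds go, is whether an amine or a carboxylic acid at the chain end keeps the step.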